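The source may hold more compounds than are shown below. What is called first, only, known or untested is meant among the compounds shown, and "the series" means these compounds.

Compound 3 `CC(C)c1ccc(-n2nc(-c3ccccc3)nc2CNc2ccc(C(=O)NO)cc2)cc1` gives 52.6% in an assay on Sf9 cells for inhibition of protein deacetylase HDAC6 (Homo sapiens), read by fluorescence, with a stated time of 40 min, tested at 100 nM (a lower number here means less inhibition, a higher number more inhibition at the concentration tested (going by the name of the read-out)), the lowest of the three numbers measured. Compound 1 `Cc1ccc(-n2nc(-c3ccccc3)nc2CNc2ccc(C(=O)NO)cc2)cc1` gives 60.7% in this assay, and compound 2 `O=C(NO)c1ccc(NCc2nc(-c3ccccc3)nn2-c2ccc(Br)cc2)cc1` gives 65.9%. The steps to compound 3 were small: a number 8.1 percentage points lower from compound 1 to compound 3 (within the scatter), and a number 13.3 percentage points lower from compound 2 to compound 3 (beyond the scatter). Compound 4 `CCc1ccc(-n2nc(-c3ccccc3)nc2CNc2ccc(C(=O)NO)cc2)cc1` differs from compound 3 by hydrogen in place of methyl on a saturated chain carbon bound to an aromatic carbon and a saturated chain carbon. For the measured compounds named here, the step that bears on this is the one from compound 1 to compound 3, where a methyl grew into an isopropyl and the number fell only within the scatter; trimming back to ethyl should therefore move the number little, at most a slight rise. The expected step is a number 3.4 percentage points higher from compound 3 to compound 4 (within the scatter), so compound 4 is estimated at 56%, within a range from 44% to 68%.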

Compound 4, a percentage reported as inhibition, at one concentration (the size of the read-out at that concentration, not a potency): 38.3%
Compound 4: middle estimate off by 17.7 percentage points, on the high side, outside the stated range (below it).
By their numbers in this assay, from the lowest: compound 4; then compounds 3, 1 and 2 (each within the scatter of the next, the first and the last beyond it).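

Ethyl on this aromatic carbon stands apart from all three earlier groups: there is a number 14.3 percentage points lower from compound 3 to compound 4 (beyond the scatter), a number 22.4 percentage points lower from compound 1 to compound 4 (beyond the scatter), and a number 27.6 percentage points lower from compound 2 to compound 4 (beyond the scatter). The number therefore does not follow chain size in a simple way, since it falls from methyl to ethyl and rises again from ethyl to isopropyl, so adding or removing a single carbon here can matter. Nothing measured here explains this dip. Going by these compounds, whether a longer chain such as n-propyl, or a methoxy group or an amine in the same place, would stay as low as compound 4 or return to the level of compound 1 remains open.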